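Swapping a Nitrobenzyl Arm for a Pyridine Ring

The source may hold more compounds than are shown below. What is called first, only, known or untested is meant among the compounds shown, and "the series" means these compounds.

Of the compounds shown here, three sharing one core have been tested in a functional assay on BJAB cells (Homo sapiens) for antiproliferative activity, with a stated time of 4 days; a higher number here means that more compound is needed for the effect, a lower number that less compound is needed. Compound 1 `Cc1nn(-c2nc(-c3ccc(Cl)c(Cl)c3)c(SC(C)C)s2)c(C(=O)O)c1Cc1ccccc1[N+](=O)[O-]` gives 20000 nM, the highest of the three numbers, though its gap to compound 2 is within the scatter. Compound 2 `CCOc1ncccc1-c1c(C)nn(-c2nc(-c3ccc(Cl)c(Cl)c3)c(SC(C)C)s2)c1C(=O)O` gives 11000 nM, and compound 3 `Cc1nn(-c2nc(-c3ccc(Cl)c(Cl)c3)c(SC(C)C)s2)c(C(=O)O)c1-c1ccncc1` gives 5900 nM. Compound 4 `Cc1nn(-c2nc(-c3ccc(Cl)c(Cl)c3)c(SC(C)C)s2)c(C(=O)O)c1-c1cccnc1` has not yet been measured.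

Going from compound 1 to compound 4, the change is pyridin-3-yl in place of 2-nitrobenzyl on an aromatic carbon. Among the compounds with values here, two measured steps bear on it. Replacing the same group by a 2-ethoxypyridin-3-yl gave a 1.8-fold lower number from compound 1 to compound 2 (0.26 log units; within the scatter), while replacing it by a pyridin-4-yl gave a 3.4-fold lower number from compound 1 to compound 3 (0.53 log units; beyond the scatter). A plain pyridin-3-yl sits between those two cases, so a modest lowering of the number is expected, roughly a 2.5-fold lower number from compound 1 to compound 4 (0.40 log units; beyond the scatter).

For compound 4 in this assay the estimate is therefore 8000 nM, with a likely range from 4000 nM to 16000 nM.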

Compound 4, half-maximal effective concentration: 12000 nM
Compound 4: the middle estimate sits 1.5-fold (0.18 log units) below what was measured, within the range that was stated.
By their numbers in this assay, from the lowest: compounds 3, 2, 4 and 1 (each within the scatter of the next, the first and the last beyond it).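

Plain pyridin-3-yl does not clearly separate from the 2-nitrobenzyl arm in this assay (a 1.7-fold lower number from compound 1 to compound 4 (0.22 log units; within the scatter)), and taking the ethoxy group off the pyridine ring also makes no clear difference (a 1.1-fold higher number from compound 2 to compound 4 (0.04 log units; within the scatter)). Within the data shown here, the one step here beyond the scatter comes from where the nitrogen sits in the pyridine ring, though it is modest: with pyridin-3-yl in place of pyridin-4-yl, the result is (a 2.0-fold higher number from compound 3 to compound 4 (0.31 log units; beyond the scatter)). No measurement available here explains why the nitrogen's place in the ring should matter.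

A pyridin-2-yl ring at this carbon would show whether the effect of the nitrogen's place extends to the third possible arrangement. Among these compounds, a pyridin-4-yl ring carrying an amine or a methoxy group would show whether the lowest number so far can be taken further.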